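Swapping a Piperazine for a Dimethylamino on an Indole Sulfonamide

A few compounds are considered here, and "the series" means these few. Any claim that something is new, unique, unknown or untested is made for them only; others in the source may bear on it.

Measured compounds:
- compound 1, `O=S(=O)(c1ccccc1)n1cc(-c2ccncc2)c2ccccc21`: 124 nM
- compound 2, `CN(C)c1cccc2c1ccn2S(=O)(=O)C1CCCCC1`: 4890 nM
- compound 3, `CN1CCN(c2ccc3c(ccn3S(=O)(=O)c3ccccc3)c2)CC1`: 27 nM

All three numbers come from an assay on isolated protein for displacement of a labelled ligand from 5-hydroxytryptamine receptor 6 (Homo sapiens), read by scintillation counting, with a stated time of 1 h; a higher number here means a weaker inhibitor, a lower number a stronger inhibitor. Among them compound 3 stands at the lowest number, so it is the strongest inhibitor of the set: compound 1 gives 124 nM, a gap beyond the scatter, and compound 2 gives 4890 nM, a much wider gap. Compound 2 differs from compound 3 in more than one place, so its two values only show that one member of the set is far weaker than the other two.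

The next compound, compound 4, `CN(C)c1ccc2c(ccn2S(=O)(=O)c2ccccc2)c1`, is compound 3 with one change: dimethylamino in place of 4-methylpiperazin-1-yl on an aromatic carbon. Within the data shown here, no pair of measured compounds shows this exact change on its own, so its effect is not known from these data. Both groups carry a nitrogen attached to the same aromatic carbon, and the phenylsulfonyl part of compound 3 is kept. A modest loss is the most likely outcome, though a result within the scatter would not surprise. For compound 4 the estimate in this assay is 60 nM, with a range from 15 nM to 250 nM. That expectation amounts to a step of a 2.2-fold higher number from compound 3 to compound 4 (0.35 log units; beyond the scatter).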

Compound 4, inhibition constant: 82 nM
For compound 4 the middle estimate is 1.4-fold (0.14 log units) below the measured one; low and high end bracket the measured number.
By their numbers in this assay, from the lowest: compound 3; then compounds 4 and 1 (each within the scatter of the next); then compound 2.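

Among these compounds, compound 3 and compound 4 are the first measured pair in this set to differ in one place only, the group on an aromatic carbon of the six-membered ring of carbon only. In this assay, dimethylamino in place of 4-methylpiperazin-1-yl gives a 3.0-fold higher number from compound 3 to compound 4 (0.48 log units; beyond the scatter), a modest step beyond the scatter, so 4-methylpiperazin-1-yl is the better of these two groups here, but its ring is not required for binding in this range. No measurement here explains the step.

The pair cannot show whether the difference comes from the ring of 4-methylpiperazin-1-yl, its second nitrogen or its methyl group, and a morpholin-4-yl, piperidin-1-yl or unmethylated piperazin-1-yl group at this place would help to separate these parts. The compounds shown also leave open how a simple primary amine or a methoxy group on this carbon would compare with dimethylamino, and whether the same swap would give a step of similar size on a different core.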